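Para-Substituent Swap on a Thiophene Amide: Cytotoxicity Outlook

The compounds below may be only part of what the source reports. "The series", "measured", "known", "first", "only" and "open" are said of these compounds alone.

Compound 1, `C/C(=C\c1cc(-c2ccc(C)cc2)cs1)C(N)=O`: in an ADME assay on NIH3T3 cells (Mus musculus) for cytotoxicity, read by CCK-8 assay, with a stated time of 24 h (a higher number here means a weaker inhibitor, a lower number a stronger inhibitor), compound 1 gives > 50000 nM, a limit of the assay rather than a number.
Compound 2, `C/C(=C\c1cc(-c2ccc(F)cc2)cs1)C(N)=O`: in this assay compound 2 gives > 50000 nM, again a limit.
Compound 3, `C/C(=C\c1cc(-c2ccc(S(C)(=O)=O)cc2)cs1)C(N)=O`: in this assay compound 3 gives > 50000 nM, also a limit.

Compound 3 therefore stands at the same limit as the other two, so no ordering among them can be read; all three sit at the limit of > 50000 nM in this assay, at which 3 of the 3 values shown sit. The steps a step that the two limits leave unreadable from compound 1 to compound 2, a step that the two limits leave unreadable from compound 1 to compound 3 and a step that the two limits leave unreadable from compound 2 to compound 3 are all unreadable for the same reason.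

Compound 4, `C/C(=C\c1cc(-c2ccc([N+](=O)[O-])cc2)cs1)C(N)=O`, differs from compound 3 by nitro in place of methylsulfonyl on an aromatic carbon. Among the measured compounds shown here, the steps that bear on this change, those leading to compound 3, carry no readable size, so no direction beyond the scatter can be predicted in this assay. The expected step of a number no higher from compound 3 to compound 4 (the limit leaves the size open) is therefore set at no change. Compound 4 is expected to give 50000 nM, within a range from 25000 nM to 100000 nM, most likely reported again as a limit.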

Compound 4, half-maximal inhibitory concentration: > 50000 nM
Compound 4 gave a limit, no number; the forecaster's own chance of this, stated with the estimate: 85%; the middle value sits exactly at the limit.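

In this assay compound 4 gives > 50000 nM, a limit and not a number. The steps to compound 4 from compound 1, compound 2 and compound 3 therefore cannot be read. Going by these compounds, how these four compounds rank against one another in this cell test remains open.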